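The source may hold more compounds than are shown below. What is called first, only, known or untested is meant among the compounds shown, and "the series" means these compounds.

Measured so far:
compound 1 `O=C(CI)NCCCCCC(=O)NCCCCCCNc1ncnc2c1ncn2[C@@H]1O[C@H](COP(=O)(O)OP(=O)(O)OP(=O)(O)O)[C@@H](O)[C@H]1O`, 0%
compound 2 `O=C(CI)NCCCCNc1ncnc2c1ncn2[C@@H]1O[C@H](COP(=O)(O)OP(=O)(O)OP(=O)(O)O)[C@@H](O)[C@H]1O`, 0%

In an assay on isolated protein for inhibition of hexokinase-2 (Rattus norvegicus), with a stated time of 6 h, tested at 10 mM (a higher number here means more inhibition at the concentration tested (going by the name of the read-out), a lower number less inhibition), compound 1 gives 0%. In this assay compound 2 gives 0%, level with compound 1 at the digits shown; the two values lie within the scatter.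

Compound 3 `O=C(CI)NCCC(=O)NCCCCCCNc1ncnc2c1ncn2[C@@H]1O[C@H](COP(=O)(O)OP(=O)(O)OP(=O)(O)O)[C@@H](O)[C@H]1O` is not yet measured. It differs from compound 2 by a group of 12 heavy atoms (7 carbon, 2 nitrogen, 2 oxygen, 1 iodine; no ring) in place of a group of 5 heavy atoms (2 carbon, 1 nitrogen, 1 oxygen, 1 iodine; no ring), on a saturated chain carbon, four bonds along the chain from a nitrogen on an aromatic ring.

Since the two measured compounds both read at the bottom of the scale, no step beyond the scatter is expected from compound 2 to compound 3, and the expected step is no change at the digits printed from compound 2 to compound 3 (within the scatter). The value expected for compound 3 is 0%, ranging from 0% to 12%.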

Compound 3, a percentage reported as inhibition, at one concentration (the size of the read-out at that concentration, not a potency): 0%
Compound 3: the middle estimate sits on the measured number at the digits printed; measured number inside the range.
By their numbers in this assay, from the lowest: compounds 1, 2 and 3 (each within the scatter of the next).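

In this assay the longer linker gives no change at the digits printed from compound 2 to compound 3 (within the scatter), with the group of 12 heavy atoms in place of ((iodomethyl)carbonyl)amino on a saturated chain carbon, four bonds along the chain from a nitrogen on an aromatic ring. With ((iodomethyl)carbonyl)amino in place of 3-(((iodomethyl)carbonyl)amino)propyl on a saturated chain carbon, two bonds along the chain from a carbonyl carbon, the series gives no change at the digits printed from compound 1 to compound 3 (within the scatter). No independent data bear on these flat results. On these data alone, whether a chloromethyl group in place of iodomethyl or a much longer chain would read above the bottom of the scale stays open.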